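Swapping sec-butyl for methylsulfanylethyl on the core of compound 1

This account rests on a few compounds, and the source may have more. Where it says the series, first, only, none or still open, it means among the compounds named here.

Compound 1, `CC[C@H](C)[C@H](NC(=O)CN(c1ncnc2c1ncn2C1CCCCO1)C1CC1)C(=O)OCc1ccccc1`, gives 22.6% in a functional assay on the whole organism (Tail, strain ICR) with Mus musculus as the target, in the tail flick test, with a stated time of 90 min, at a dose of 25 umol/kg by the oral route; a lower number here means a weaker effect, a higher number a stronger effect of the compound at the dose given.
Compound 2, `O=C(CN(c1nc(Cl)nc2[nH]cnc12)C1CC1)N[C@@H](CCC(=O)OCc1ccccc1)C(=O)OCc1ccccc1`, gives 50% in this assay.
Compound 3, `CSCC[C@H](NC(=O)CN(c1nc(Cl)nc2[nH]cnc12)C1CC1)C(=O)OCc1ccccc1`, gives 44.6% in this assay.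

Among these three, compound 1 stands lowest: both compound 3 and compound 2 lie beyond the scatter above it. The step to the unmeasured compound 4, `CSCC[C@H](NC(=O)CN(c1ncnc2c1ncn2C1CCCCO1)C1CC1)C(=O)OCc1ccccc1`, is 2-(methylsulfanyl)ethyl in place of sec-butyl on a saturated chain carbon bound to an amide-type nitrogen and a carbonyl carbon. Among the compounds with values here, no measured pair shares exactly this change. The nearest comparison is a number 5.4 percentage points lower from compound 2 to compound 3 (within the scatter), in which a different group gave way to the methylsulfanyl chain on the core of compound 2, and the reading barely moved. Compound 3 thus carries the same side chain that compound 4 will carry, but on a different core, so the data give no direct guide to how that chain behaves on the core of compound 1. Given that the one measured side-chain exchange stayed within the scatter, the step of a number 5.4 percentage points higher from compound 1 to compound 4 (within the scatter) is expected to be small, with a slight upward lean at most. Compound 4 is estimated at 28%, between 14% and 45% in this assay.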

Compound 4, a percentage reported as activity, at one dose (the size of the read-out at that dose, not a potency): 42.7%
The estimate for compound 4 lay 14.7 percentage points below the measured number; the measured number falls inside the stated range.
By their numbers in this assay, from the lowest: compound 1; then compounds 4, 3 and 2 (each within the scatter of the next).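

On the core of compound 1, the saturated chain carbon bound to an amide-type nitrogen and a carbonyl carbon responds to its side chain: in this assay, 2-(methylsulfanyl)ethyl in place of sec-butyl gives a number 20.1 percentage points higher from compound 1 to compound 4 (beyond the scatter) on that core. Within the data shown here, the only earlier exchange at this carbon, a number 5.4 percentage points lower from compound 2 to compound 3 (within the scatter) on another core, removed a different group, so the two steps do not read as one change. Nothing measured on these compounds bears on why the reading moved.

Going by these compounds, it remains open whether the sulfur matters or the loss of sec-butyl alone, a question that a 2-methoxyethyl or longer chain at this carbon would address. Also open, on these data alone, is how an amine or a carboxylic acid on that chain would read.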